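Lipophilicity notes on compounds 1 to 4

This account rests on a few compounds, and the source may have more. Where it says the series, first, only, none or still open, it means among the compounds named here.

Compound 1, `CCOc1ccccc1-c1ccc(-c2nc3cnccc3c(N[C@H](CC)C(N)=O)c2C#N)cc1`: in a physicochemical assay for lipophilicity, read by HPLC, at pH 7.5 (a higher number here means a more lipophilic compound, a lower number a more polar compound), compound 1 gives 3.
Compound 2, `CCOc1ccccc1-c1ccc(-c2nc3cnccc3c(NC(COC)C(N)=O)c2C#N)cc1`: in this assay compound 2 gives 2.8.
Compound 3, `CCOc1ccccc1-c1ccc(-c2nc3cnccc3c(C[C@H](C)C(=O)O)c2C#N)cc1`: in this assay compound 3 gives 2.2.

Compound 3 stands lowest of the three: a number 0.80 log units lower from compound 1 to compound 3 (beyond the scatter) and a number 0.60 log units lower from compound 2 to compound 3 (beyond the scatter), both beyond the scatter, while a number 0.20 log units lower from compound 1 to compound 2 (within the scatter) lies within it. Compound 4, `CCOc1ccccc1-c1ccc(-c2nc3cnccc3c(NC(C(N)=O)C3CC3)c2C#N)cc1`, is not yet measured. Its change from compound 3: a group of 8 heavy atoms (5 carbon, 2 nitrogen, 1 oxygen; one three-membered non-aromatic ring of carbon only) in place of a group of 6 heavy atoms (4 carbon, 2 oxygen; no ring), on an aromatic carbon. This change largely reverses the two steps that led to compound 3, restoring an amino-amide side group as in compounds 1 and 2; the swap of 1-carbamoylpropyl for 1-carbamoyl-2-methoxyethyl moved little. A modest rise in this assay is therefore expected, a number 0.80 log units higher from compound 3 to compound 4 (beyond the scatter), back to the level of compounds 1 and 2. Compound 4 is estimated at 3, in the range 2.6 to 3.4.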

Compound 4, distribution coefficient: 3
Beside the measured number, compound 4's estimate shows no gap at the digits printed; measured number inside the range.
By their numbers in this assay, from the lowest: compound 3; then compounds 2, 1 and 4 (each within the scatter of the next).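

In this assay, cyclopropyl on the chain carbon bound to a carbonyl carbon and the ring nitrogen substituent reads level with methoxymethyl (a number 0.20 log units higher from compound 2 to compound 4 (within the scatter)) and with the chain of compound 1 (no change at the digits printed from compound 1 to compound 4 (within the scatter)). A three-membered ring of carbon is therefore accepted at this chain carbon with no step beyond the scatter. The separation of compound 3 now holds against a third side group (a number 0.80 log units higher from compound 3 to compound 4 (beyond the scatter)).

Compound 3 changes the nitrogen link and the end group at once; a carboxylic acid on a nitrogen-linked chain, or an amine in place of the carbamoyl group, would separate the two. No evidence shown bears on the cause of these numbers.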